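This account rests on a few compounds, and the source may have more. Where it says the series, first, only, none or still open, it means among the compounds named here.

For the measured compounds named here, in a functional assay on MM1.S cells (Homo sapiens) for inhibition, with a stated time of 72 h (on this read-out lower numbers stand for stronger inhibition and higher numbers for weaker inhibition), compound 1 (`CC(C)N(Cc1ccc(C(=O)NO)cc1)S(=O)(=O)c1c(F)c(F)c(F)c(F)c1F`) gives 440 nM and compound 2 (`COCCN(Cc1ccc(C(=O)NO)cc1)S(=O)(=O)c1cc(F)c(F)c(F)c1F`) gives 710 nM as the only numbers so far. These two values lie within the usual scatter of each other, so compound 2 cannot be separated from compound 1 on the data at hand. Going by the values given here, the two compounds differ in more than one place, and no measured pair isolates a single change.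

Compound 3 (`CC(C)N(Cc1ccc(C(=O)NO)cc1)S(=O)(=O)c1cc(F)c(F)c(F)c1F`) is compound 2 with isopropyl in place of 2-methoxyethyl on a sulfonamide nitrogen. Among the compounds with values here, the only measured compound carrying isopropyl on that nitrogen is compound 1 at 440 nM in this assay, and that value offers no sign of a large shift. No effect beyond the scatter is therefore expected for this change, with only a slight lean towards a lower number. The expected step of a 1.4-fold lower number from compound 2 to compound 3 (0.15 log units; within the scatter) stays within the scatter. For compound 3 the estimated value is 500 nM (200 nM to 1200 nM).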

Compound 3, half-maximal inhibitory concentration: 1380 nM
Compound 3: the middle estimate sits 2.8-fold (0.44 log units) below what was measured; measured number above the stated range.
By their numbers in this assay, from the lowest: compounds 1, 2 and 3 (each within the scatter of the next, the first and the last beyond it).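

In this assay, for the compounds shown here, compound 1 and compound 3 form the first pair that isolates a single change, hydrogen in place of fluoro on an aromatic carbon, with isopropyl on the sulfonamide nitrogen held constant; this gives the first step beyond the scatter, a modest one (a 3.1-fold higher number from compound 1 to compound 3 (0.50 log units; beyond the scatter)). At the sulfonamide nitrogen, isopropyl in place of 2-methoxyethyl stays within the scatter (a 1.9-fold higher number from compound 2 to compound 3 (0.29 log units; within the scatter)), so this pair does not separate the two groups on the one fluoro pattern where both are present. No measured information on the compounds bears on either step.

Going by these compounds, whether the fluoro to hydrogen step recurs with 2-methoxyethyl on the sulfonamide nitrogen remains open, as a single pair gives one reading at one aromatic carbon and says nothing about a series-wide trend. Also open, on these data alone, is how other groups would read in this cell assay, such as a longer chain or a chain ending in an amine on the sulfonamide nitrogen, or chloro or methoxy in place of fluoro on that aromatic carbon.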